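Adding a Hydroxy to the Dimethoxyphenyl Amide

The source may hold more compounds than are shown below. What is called first, only, known or untested is meant among the compounds shown, and "the series" means these compounds.

Compound 1 `O=C(/C=C/c1cccc(Cl)c1Cl)Nc1cc2c(Nc3ccc(F)c(Cl)c3)ncnc2cc1O[C@H]1CCOC1`: 23200 nM
Compound 2 `COc1ccc(/C=C/C(=O)Nc2cc3c(Nc4ccc(F)c(Cl)c4)ncnc3cc2O[C@H]2CCOC2)c(OC)c1`: 9350 nM
Compound 3 `COc1cc(/C=C/C(=O)Nc2cc3c(Nc4ccc(F)c(Cl)c4)ncnc3cc2O[C@H]2CCOC2)cc(OC)c1`: 10800 nM

In a functional assay on A549 cells (Homo sapiens) for cytotoxicity, read by MTT assay, with a stated time of 72 h (on this read-out higher numbers stand for weaker inhibition and lower numbers for stronger inhibition), compound 3 belongs to the lower pair of the three numbers. Rearranging the methoxy groups gave a 1.2-fold higher number from compound 2 to compound 3 (0.06 log units; within the scatter), whereas exchanging the dichlorophenyl group gave a 2.1-fold lower number from compound 1 to compound 3 (0.33 log units; beyond the scatter) and a 2.5-fold lower number from compound 1 to compound 2 (0.39 log units; beyond the scatter).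

Compound 4 `COc1cc(/C=C/C(=O)Nc2cc3c(Nc4ccc(F)c(Cl)c4)ncnc3cc2O[C@H]2CCOC2)cc(OC)c1O` differs from compound 3 by hydroxy in place of hydrogen on an aromatic carbon, turning 3,5-dimethoxyphenyl into 4-hydroxy-3,5-dimethoxyphenyl. Within the data shown here, no measured compound carries a hydroxy, so no step tests this change directly, and the direction stays open. All measured changes on this ring were small or modest, so no shift beyond the scatter is expected in this assay. The expected step is a 1.2-fold lower number from compound 3 to compound 4 (0.08 log units; within the scatter). For compound 4 the estimated value is 9000 nM, with an expected range of 3500 nM to 23000 nM.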

Compound 4, half-maximal inhibitory concentration: 27000 nM
Estimate against measurement, compound 4: 3.0-fold (0.48 log units) below, and the stated range ends below it.
By their numbers in this assay, from the lowest: compounds 2 and 3 (each within the scatter of the next); then compounds 1 and 4 (each within the scatter of the next).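

In this assay, adding one hydroxy ortho to two methoxy groups moves the number beyond the scatter (a 2.5-fold higher number from compound 3 to compound 4 (0.40 log units; beyond the scatter)). The shift is similar against the other dimethoxy compound (a 2.9-fold higher number from compound 2 to compound 4 (0.46 log units; beyond the scatter)), while the gap to the dichlorophenyl compound lies within the scatter (a 1.2-fold higher number from compound 1 to compound 4 (0.07 log units; within the scatter)), so the lower numbers of the dimethoxy compounds do not survive this addition. Nothing available explains the rise.

Going by these compounds, it remains open whether this rise is specific to the hydroxy or would also follow from another group at this position, such as an amine or a third methoxy.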